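The source may hold more compounds than are shown below. What is called first, only, known or untested is meant among the compounds shown, and "the series" means these compounds.

In an ADME assay on cells (Macrophage) for cytotoxicity, read by MTT assay, with a stated time of 24 h (on this read-out lower numbers stand for higher toxicity in this test and higher numbers for lower toxicity in this test), three compounds of one shared core have been measured:

Compound 1 `COc1ccc(/C=C/C(=O)NNC(=O)c2ccc3c(c2)OCCO3)cc1`: 319000 nM
Compound 2 `O=C(/C=C/c1ccc(Br)cc1)NNC(=O)c1ccc2c(c1)OCCO2`: 259000 nM
Compound 3 `O=C(/C=C/c1cccc(F)c1)NNC(=O)c1ccc2c(c1)OCCO2`: 221000 nM

Compound 1 stands highest of these three numbers, yet neither step away from it reaches beyond the usual scatter: a 1.2-fold lower number from compound 1 to compound 2 (0.09 log units; within the scatter), and a 1.4-fold lower number from compound 1 to compound 3 (0.16 log units; within the scatter). The remaining pair behaves the same way, with a 1.2-fold lower number from compound 2 to compound 3 (0.07 log units; within the scatter). Across these three compounds, then, swapping the group on the double-bonded chain carbon has not moved the read-out by more than repeat measurements would.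

Compound 4 `O=C(/C=C/c1ccccc1F)NNC(=O)c1ccc2c(c1)OCCO2` is the next member of the set. Compared with compound 1 it carries 2-fluorophenyl in place of 4-methoxyphenyl on a double-bonded chain carbon bound to a double-bonded chain carbon. The step from compound 1 to compound 3 bears most directly on it, since that step also exchanged the 4-methoxyphenyl for a fluorophenyl, and it stayed within the scatter; the step from compound 1 to compound 2 points the same way. No change beyond the scatter in this assay is therefore expected here, and any drift is expected to be slight and downward, as a 1.3-fold lower number from compound 1 to compound 4 (0.11 log units; within the scatter). For compound 4 the expected value is 250000 nM, with a likely range from 150000 nM to 400000 nM.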

Compound 4, half-maximal cytotoxic concentration: 302000 nM
Beside the measured number, compound 4's estimate is 1.2-fold (0.08 log units) below it; low and high end bracket the measured number.
By their numbers in this assay, from the lowest: compounds 3, 2, 4 and 1 (each within the scatter of the next).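

In this assay, among the compounds shown here, the new result adds a comparison the earlier compounds could not give, two fluorophenyl groups that differ only in where the fluorine sits: 2-fluorophenyl in place of 3-fluorophenyl gives a 1.4-fold higher number from compound 3 to compound 4 (0.14 log units; within the scatter) and stays within the scatter, so this read-out does not separate the two groups. The comparisons with the other two groups agree, with 2-fluorophenyl in place of 4-methoxyphenyl giving a 1.1-fold lower number from compound 1 to compound 4 (0.02 log units; within the scatter) and 2-fluorophenyl in place of 4-bromophenyl giving a 1.2-fold higher number from compound 2 to compound 4 (0.07 log units; within the scatter), so all four substituted phenyl groups on this double-bonded chain carbon now lie within the scatter of one another. Nothing measured here offers an explanation for this flat picture.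

As far as these compounds go, all four compounds keep a substituted phenyl ring at this place, so it remains open whether a group of another kind, such as an amine, a carboxylic acid or a longer chain, would move the number beyond the scatter. The compounds shown also share the rest of the core of compound 1 , so they say nothing about how a change elsewhere in the molecule would register in this assay.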